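Hydroxy in place of hydrogen on the methoxy core

This account rests on a few compounds, and the source may have more. Where it says the series, first, only, none or still open, it means among the compounds named here.

Compound 2 `COc1ccc2ncc(C(=O)O)cc2c1` stands at a limit in a functional assay on the whole organism (strain Sprague-Dawley) for inhibition, with Rattus norvegicus as the target (a higher number here means that more compound is needed for the effect, a lower number that less compound is needed), where compound 2 gives > 5 mg/kg; this is the limit of > 5 mg/kg in this assay, at which 1 of the 3 values shown sits. Compound 1 `O=C(O)c1cnc2ccc(C3CCCCC3)cc2c1` gives in this assay only the limit > 25 mg/kg. Compound 3 `O=C(O)c1cnc2ccc(C(F)(F)F)cc2c1` likewise gives in this assay only the limit > 25 mg/kg. These two values are the limit of > 25 mg/kg in this assay, at which 2 of the 3 values shown sit. Compound 4 `COc1ccc2ncc(C(=O)O)c(O)c2c1` carries on the core of compound 2 the change (hydroxy in place of hydrogen on an aromatic carbon). The steps that could bear on it, a step that the two limits leave unreadable from compound 1 to compound 2, a step that the two limits leave unreadable from compound 1 to compound 3 and a step that the two limits leave unreadable from compound 2 to compound 3, are all unreadable, so no size and no direction can be expected beyond the scatter. Compound 4 is therefore estimated at 10 mg/kg, within 3 mg/kg to 50 mg/kg, most probably again reported only as a limit. The expected step that the limit leaves unreadable from compound 2 to compound 4 is taken as none beyond the scatter.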

Compound 4, minimum effective dose: > 50 mg/kg
Compound 4: a limit, no number (the forecaster's own chance of this, stated with the estimate: 70%); at least 5.0-fold (0.69 log units) between middle value and limit.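

Compound 2 gives only the limit > 5 mg/kg. Within the data shown here, compound 4 gives only the limit > 50 mg/kg, so no step from compound 2 can be read. As far as these compounds go, whether hydroxy in place of hydrogen changes the minimum effective dose at all, and in which direction, stays open.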